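Cytotoxicity in the series: swapping the imidazolyl for a bicycle

A few compounds are considered here, and "the series" means these few. Any claim that something is new, unique, unknown or untested is made for them only; others in the source may bear on it.

Compound 2 `Cc1cc(-n2ccnc2)cn2c(CSCCc3ccccc3)cnc12` stands highest of the two numbers in an ADME assay on HEL cells (Homo sapiens) for cytotoxicity, with a stated time of 3 days; a lower number here means that less compound is tolerated, a higher number that more compound is tolerated: compound 2 gives 100 ug/mL, while compound 1 `C=Cc1ccc(-c2cc(C)c3ncc(CSCCc4ccccc4)n3c2)cc1` gives 20 ug/mL. Among the measured compounds shown here, the one measured step, a 5.0-fold higher number from compound 1 to compound 2 (0.70 log units; beyond the scatter), concerns the same aromatic carbon. Compound 3 `Cc1cc(-n2ccc3cccnc32)cn2c(CSCCc3ccccc3)cnc12` carries a group of 9 heavy atoms (7 carbon, 2 nitrogen; one five-membered aromatic ring with 1 hetero atom, one six-membered aromatic ring with 1 hetero atom) in place of a group of 5 heavy atoms (3 carbon, 2 nitrogen; one five-membered aromatic ring with 2 hetero atoms), on an aromatic carbon. For the measured compounds named here, no step covers this exact exchange; the only guide is that the larger aromatic substituent in compound 1 went with the lower number 20 ug/mL. A modest fall is therefore expected, a 2.0-fold lower number from compound 2 to compound 3 (0.30 log units; within the scatter), and compound 3 is estimated at 50 ug/mL, with a range of 20 ug/mL to 100 ug/mL.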

Compound 3, minimum cytotoxic concentration: 20 ug/mL
Beside the measured number, compound 3's estimate is 2.5-fold (0.40 log units) above it; the measured number falls inside the stated range.
By their numbers in this assay, from the lowest: compounds 1 and 3 (each within the scatter of the next); then compound 2.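

In this assay, exchanging 1H-imidazol-1-yl for the larger group with one five-membered and one six-membered aromatic ring gives a 5.0-fold lower number from compound 2 to compound 3 (0.70 log units; beyond the scatter). Exchanging 4-vinylphenyl for that same group gives no change at the digits printed from compound 1 to compound 3 (within the scatter), so the two larger groups on this aromatic carbon sit level, and only compound 2 stands apart. Nothing available explains this difference.

Still open, on these data alone, is whether the higher number is particular to 1H-imidazol-1-yl. An amine or a carboxylic acid on this aromatic carbon could fall with compound 2 or with compound 1 and compound 3.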